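A few compounds are considered here, and "the series" means these few. Any claim that something is new, unique, unknown or untested is made for them only; others in the source may bear on it.

Working notes on the ester series.

In a functional assay on U-251 cells (Homo sapiens) for antiproliferative activity, read by sulforhodamine B assay, with a stated time of 48 h, tested at 50 uM (a higher number here means more inhibition at the concentration tested (going by the name of the read-out), a lower number less inhibition), compound 1 `COc1cccc(C(=O)Oc2cc3c(cc2C)[C@@H](C(C)C)CC=C3C)c1` is recorded as "not active" (no number reported), so no single number stands for it and its position can only be given as falling short of a reportable value. Compound 2 `CC1=CC[C@H](C(C)C)c2cc(C)c(OC(=O)c3ccccc3)cc21`, which carries the unsubstituted ester, gives 25.8% in this assay. Nothing else in the set allows the gap between compound 1 and compound 2 to be read as a step.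

Compound 3 `CC1=CC[C@H](C(C)C)c2cc(C)c(OC(=O)c3cccc([N+](=O)[O-])c3)cc21` differs from compound 1 by nitro in place of methoxy on an aromatic carbon. Among the measured compounds shown here, no measured pair shows this change, so the size of the step in this assay cannot be drawn from the data; the expectation is a shift of no more than the usual scatter, in either direction, from wherever compound 1 actually lies. On that basis compound 3 is expected to give about 18% in this assay, with a range from 0% to 42%.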

Compound 3, a percentage reported as inhibition, at one concentration (the size of the read-out at that concentration, not a potency): 44%
The estimate for compound 3 lay 26 percentage points below the measured number; measured number above the stated range.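

In this assay, nitro in place of hydrogen on an aromatic carbon gives a number 18.2 percentage points higher from compound 2 to compound 3 (beyond the scatter), so this place on the ester's aromatic ring does respond to substitution, and a substituent there can go with more inhibition than the unsubstituted ester. With methoxy at the same place, compound 1 is recorded as "not active" (no number reported), whereas compound 3 carries a reportable number, so the 3-methoxyphenyl and 3-nitrophenyl esters are not interchangeable here, although the size of that gap cannot be read. Nothing available explains the difference between these groups.

On these data alone, whether an amine or a carboxylic acid at this place would read closer to nitro or to methoxy remains open. So does whether nitro at another carbon of this ring would give a similar step.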